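Aryl swap on the shared core: compound 2 to compound 4

The source may hold more compounds than are shown below. What is called first, only, known or untested is meant among the compounds shown, and "the series" means these compounds.

Three analogues share one core and differ only in the aryl group attached to it. In an assay for displacement of a labelled ligand from melanin-concentrating hormone receptor 1 (Homo sapiens), read by fluorescence (on this read-out higher numbers stand for weaker inhibition and lower numbers for stronger inhibition), compound 1 `CC(=O)Nc1cccc(C2CCN(CCCn3c(-c4ccccc4Cl)nc4ccccc43)CC2)c1` gives 10 nM. In this assay compound 2 `CC(=O)Nc1cccc(C2CCN(CCCn3c(-c4cccc(C(F)(F)F)c4)nc4ccccc43)CC2)c1` gives 30 nM. In this assay compound 3 `COc1ccc(-c2nc3ccccc3n2CCCN2CCC(c3cccc(NC(C)=O)c3)CC2)cc1` gives 9 nM. Compound 2 therefore carries the highest number of the three: the step of a 3.0-fold higher number from compound 1 to compound 2 (0.48 log units; beyond the scatter) and the step of a 3.3-fold lower number from compound 2 to compound 3 (0.52 log units; beyond the scatter) both lie beyond the scatter, whereas the step of a 1.1-fold lower number from compound 1 to compound 3 (0.05 log units; within the scatter) stays within it.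

Compound 4 `CC(=O)Nc1cccc(C2CCN(CCCn3c(-c4ccc(Cl)cc4F)nc4ccccc43)CC2)c1` has not yet been measured. It differs from compound 2 in a single place: 4-chloro-2-fluorophenyl in place of 3-(trifluoromethyl)phenyl on an aromatic carbon. For the measured compounds named here, two measured steps bear on this change, both of them exchanges of the aryl group on the same carbon of the core. The step of a 3.3-fold lower number from compound 2 to compound 3 (0.52 log units; beyond the scatter) was modest, and the step of a 3.0-fold higher number from compound 1 to compound 2 (0.48 log units; beyond the scatter), read from the side of compound 2, was modest as well. Each exchange that removed the 3-(trifluoromethyl)phenyl, or had not yet introduced it, sat at the lower number. A modest fall in this assay is therefore expected for compound 4, of about a 2.5-fold lower number from compound 2 to compound 4 (0.40 log units; beyond the scatter). For compound 4 the estimate in this assay is 12 nM, expected to lie between 4 nM and 40 nM.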

Compound 4, half-maximal inhibitory concentration: 1 nM
For compound 4 the middle estimate is 12-fold (1.08 log units) above the measured one; measured number outside the range, below it.
By their numbers in this assay, from the lowest: compound 4; then compounds 3 and 1 (each within the scatter of the next); then compound 2.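

In this assay, for the compounds shown here, the aryl group on the shared core proves a much stronger lever than the earlier compounds suggested: 4-chloro-2-fluorophenyl gives a 30-fold lower number from compound 2 to compound 4 (1.48 log units; beyond the scatter), and also a 9.0-fold lower number from compound 3 to compound 4 (0.95 log units; beyond the scatter) and a 10-fold lower number from compound 1 to compound 4 (1.00 log units; beyond the scatter), which leaves compound 4 with the lowest number of the four, beyond the scatter from each of the others. The 2-chlorophenyl of compound 1 and the 4-methoxyphenyl of compound 3 stay level, so the earlier compounds gave no sign of this range, and a chlorine on the ring is not enough by itself, as compound 1 shows; among these four, only the aryl group of compound 4 carries two ring substituents. No measurement shown here explains why this aryl group stands apart from the other three.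

The compounds shown leave open whether the chlorine, the fluorine or the pair of them accounts for the step, since all three other aryl groups differ from 4-chloro-2-fluorophenyl in more than one respect. They also leave open how this position responds to an amine or a carboxylic acid on the aryl ring.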